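Working notes: 2,4-dichlorophenyl in place of 3,4-dihydroxyphenyl

This account rests on a few compounds, and the source may have more. Where it says the series, first, only, none or still open, it means among the compounds named here.

Measured so far in a functional assay on HepG2 cells (Homo sapiens) for cytotoxicity, read by MTT assay, with a stated time of 48 h; on this read-out lower numbers stand for stronger inhibition and higher numbers for weaker inhibition:
- compound 1 `O=C(CSc1nnc(-c2ccncc2)o1)N/N=C/c1ccccc1F`: 16000 nM
- compound 2 `O=C(CSc1nnc(-c2ccncc2)o1)N/N=C/c1cc(Br)cc(Br)c1O`: 6540 nM
- compound 3 `O=C(CSc1nnc(-c2ccncc2)o1)N/N=C/c1ccc(O)c(O)c1`: 760 nM

Compound 3 has the lowest number of the three, at 760 nM, and its separation from each of the other two lies beyond the scatter.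

The next compound is compound 4 `O=C(CSc1nnc(-c2ccncc2)o1)N/N=C/c1ccc(Cl)cc1Cl`, with 2,4-dichlorophenyl in place of 3,4-dihydroxyphenyl on a carbon with a double bond to nitrogen. Its difference from compound 3 is 2,4-dichlorophenyl in place of 3,4-dihydroxyphenyl on a carbon with a double bond to nitrogen. Among the compounds with values here, no measured compound carries 2,4-dichlorophenyl, so the estimate rests on neighbouring changes at the same place.

Two measured steps bring in 3,4-dihydroxyphenyl: a 21-fold lower number from compound 1 to compound 3 (1.32 log units; beyond the scatter), which is large, and an 8.6-fold lower number from compound 2 to compound 3 (0.93 log units; beyond the scatter), which is modest. Read in reverse, both suggest that losing this group raises the number. The step between the two halogen-bearing compounds, a 2.4-fold lower number from compound 1 to compound 2 (0.39 log units; beyond the scatter), is smaller than either, so the number for compound 4 is expected to fall near those of compound 1 and compound 2 rather than near that of compound 3.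

In this assay, the expected change is a 12-fold higher number from compound 3 to compound 4 (1.07 log units; beyond the scatter), a clear move toward a higher number. For compound 4 the estimated value is 9000 nM, with an expected range from 3000 nM to 25000 nM.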

Compound 4, half-maximal inhibitory concentration: 18600 nM
Compound 4: the middle estimate sits 2.1-fold (0.32 log units) below what was measured; the range from low to high includes it.
By their numbers in this assay, from the lowest: compound 3; then compound 2; then compounds 1 and 4 (each within the scatter of the next).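

Notes on the result: in this assay, the change to 2,4-dichlorophenyl, which has no hydrogen-bond donors or acceptors, gives a 24-fold higher number from compound 3 to compound 4 (1.39 log units; beyond the scatter) and shows that the low number of compound 3 is not kept by a ring of the same heavy-atom count carrying chlorine in place of oxygen. The halogen rings do not all behave alike at this position: a 1.2-fold higher number from compound 1 to compound 4 (0.07 log units; within the scatter) leaves the two rings that carry only halogen inseparable, while a 2.8-fold higher number from compound 2 to compound 4 (0.45 log units; beyond the scatter) keeps compound 2, with its 3,5-dibromo-2-hydroxyphenyl ring, apart from compound 4. Thus the three hydroxy-bearing and hydroxy-free rings now order as compound 3, then compound 2, then compounds 1 and 4 together, and nothing available explains that order.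

On these data alone, whether the low number of compound 3 depends on both hydroxy groups or on one remains open, and compound 2 cannot settle this, as its ring also carries bromine. Also open, as far as these compounds go, is how a methoxy group or an amine on the same ring, in place of a hydroxy group, would fall in this order.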